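A few compounds are considered here, and "the series" means these few. Any claim that something is new, unique, unknown or untested is made for them only; others in the source may bear on it.

Measured compounds in an ADME assay on L02 cells (Homo sapiens) for cytotoxicity, read by MTT assay, with a stated time of 48 h; on this read-out lower numbers stand for stronger inhibition and higher numbers for weaker inhibition:

- compound 1 `COc1ccc2[nH]c(=O)c(-c3nc4cc(C)c(C)cc4[nH]3)cc2c1`: > 100000 nM
- compound 2 `Cc1ccc2[nH]c(=O)c(-c3nc4cc(C)c(C)cc4[nH]3)cc2c1`: > 100000 nM

Compound 2 stands at a limit of this assay rather than at a number, its value being > 100000 nM. Compound 1 likewise sits at a limit in this assay, giving > 100000 nM. Both values therefore coincide at the same point, as summarised by the limit of > 100000 nM in this assay, at which 2 of the 2 values shown sit, and the change from methoxy to methyl between them, a step that the two limits leave unreadable from compound 1 to compound 2, cannot be sized from the two limits.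

Compound 3 `Cc1cc2nc(-c3cc4ccccc4[nH]c3=O)[nH]c2cc1C` differs from compound 2 by hydrogen in place of methyl on an aromatic carbon, a small trimming of the shared core. For the measured compounds named here, the only measured step, a step that the two limits leave unreadable from compound 1 to compound 2, concerns a different position and is itself unreadable, so no measured step reports how this assay responds to changes on this ring; nothing in the available numbers points to a step in either direction.

Compound 3 is therefore expected to remain at or near the limit, with an estimated step that the limit leaves unreadable from compound 2 to compound 3 from compound 2. The estimate for compound 3 in this assay is 150000 nM, within a range of 40000 nM to 600000 nM.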

Compound 3, half-maximal inhibitory concentration: > 100000 nM
Compound 3: only a limit was reported; the forecaster's own chance of this, stated with the estimate: 80%; the middle value lies beyond the limit too.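

In this assay compound 3 gives > 100000 nM, which is a limit and not a number. For the compounds shown here, no step among compound 1, compound 2 and compound 3 can be read: the limit of > 100000 nM in this assay, at which 3 of the 3 values shown sit. The compounds shown leave open how far each lies from this limit, and whether any change on the shared core would yield a measurable value.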